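Dithiocarbamate chromones: amine swap on a second core

A few compounds are considered here, and "the series" means these few. Any claim that something is new, unique, unknown or untested is made for them only; others in the source may bear on it.

Measured compounds:
- compound 1, `COc1ccc2oc(CSC(=S)N3CCOCC3)cc(=O)c2c1`: 3400 nM
- compound 2, `COc1ccc2oc(CSC(=S)N(C(C)C)C(C)C)cc(=O)c2c1`: 22100 nM
- compound 3, `O=c1c(CSC(=S)N2CCOCC2)coc2ccccc12`: 3900 nM

All three were run in a functional assay on MDA-MB-435S cells (Homo sapiens) for antiproliferative activity, read by MTT assay, with a stated time of 72 h; a lower number here means a stronger inhibitor, a higher number a weaker inhibitor. Compound 1 and compound 3 share a dithiocarbamate-bearing arm ending in a morpholin-4-yl group; how their two cores differ is not broken down here. Their values lie within the scatter of each other, so no order between compound 1 and compound 3 is drawn.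

Compound 2 differs from compound 1 by a single change, (diisopropylamino in place of morpholin-4-yl on a thiocarbonyl carbon), and this gives a 6.5-fold higher number from compound 1 to compound 2 (0.81 log units; beyond the scatter).

Compound 4, `CC(C)N(C(=S)SCc1coc2ccccc2c1=O)C(C)C`, is not yet measured. It stands to compound 3 as compound 2 stands to compound 1: the change is diisopropylamino in place of morpholin-4-yl on a thiocarbonyl carbon, and since the two "place" descriptions match word for word, it is the same change, made on the core of compound 3 rather than that of compound 1.

The expectation for compound 4 in this assay rests on one precedent only, the pair compound 1 to compound 2, where the same change produced a 6.5-fold higher number from compound 1 to compound 2 (0.81 log units; beyond the scatter); it is therefore estimated that compound 4 shows a step of about a 5.6-fold higher number from compound 3 to compound 4 (0.75 log units; beyond the scatter). With compound 3 as the starting point, compound 4 is expected to give roughly 22000 nM, within a range estimated from 9000 nM to 55000 nM. The change is seen only once in a measured pair. The range is kept wide.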

Compound 4, half-maximal inhibitory concentration: 7900 nM
Beside the measured number, compound 4's estimate is 2.8-fold (0.44 log units) above it; the measured number lies below the stated range.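

In this assay diisopropylamino in place of morpholin-4-yl on a thiocarbonyl carbon gives a 2.0-fold higher number from compound 3 to compound 4 (0.31 log units; beyond the scatter) and so moves the number in the same direction as on the core of compound 1. The direction of the step carries over to the second core, but its size does not: the same change on two cores in this assay, a 6.5-fold higher number (0.81 log units; beyond the scatter) from compound 1 to compound 2 and a 2.0-fold higher number (0.31 log units; beyond the scatter) from compound 3 to compound 4, 3.2-fold (0.51 log units) apart, beyond the scatter of two such steps

These two pairs show that a step measured on one core is a poor guide to the size of the same step on another core in this series, but they do not show what in the two cores sets that size, nor whether the direction would hold on any further core.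

The compounds shown carry only two amine ends on the dithiocarbamate, morpholin-4-yl and diisopropylamino, so it remains open whether a smaller open-chain amine such as dimethylamino or diethylamino would give a step that also depends on the core. Also open, on these data alone, is whether a longer chain joining the sulfur to the core would alter the step on either core.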